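The source may report more compounds than this note shows. Statements on the series, on what has been measured and on what is new or still open speak of the compounds shown alone.

Series notes. Three amides on the shared core have so far been measured in an in vitro assay on cells for inhibition of Amine oxidase [flavin-containing] B (Homo sapiens), read by fluorescence and Amplex Red, with stated times of 30 min and 45 min; on this read-out higher numbers stand for weaker inhibition and lower numbers for stronger inhibition. Compound 1 `CN(C(=O)CCCc1ccccc1)c1nc2ccccc2c(=O)s1` gives 53.1 nM. Compound 2 `O=C(CCc1ccccc1)Nc1nc2ccccc2c(=O)s1` gives 17.6 nM, the lowest of the three numbers, with compound 1 nearest and compound 3 furthest, both gaps beyond the scatter. Compound 3 `O=C(/C=C/c1cccc(Cl)c1)Nc1nc2ccccc2c(=O)s1` gives 93.3 nM. Compound 4 `O=C(CCc1ccccc1Br)Nc1nc2ccccc2c(=O)s1` is not yet measured; it differs from compound 2 by bromo in place of hydrogen on an aromatic carbon. For the measured compounds named here, no pair of measured compounds differs in a single place, so no measured step guides this change. For compound 4 the expected step is a 1.4-fold higher number from compound 2 to compound 4 (0.15 log units; within the scatter), small and leaning toward a slightly higher number. Compound 4 is accordingly expected to give about 25 nM in this assay, within a range of 8 nM to 80 nM.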

Compound 4, half-maximal inhibitory concentration: 2.09 nM
Compound 4: middle estimate off by 12-fold (1.08 log units), on the high side, outside the stated range (below it).
By their numbers in this assay, from the lowest: compound 4; then compound 2; then compounds 1 and 3 (each within the scatter of the next).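

In this assay, bromo in place of hydrogen on an aromatic carbon, ortho to a large group, gives an 8.4-fold lower number from compound 2 to compound 4 (0.93 log units; beyond the scatter). For the compounds shown here, this is the first single-place step, and it shows that this ring position accepts a bromine atom and that the change strengthens inhibition beyond the scatter. No measured evidence accounts for the size of this step.

Going by these compounds, whether chloro, methyl or methoxy on the same carbon gives a step of similar size stays open. Also open, on these data alone, is whether bromo has a like effect on the chains of compound 1 and compound 3.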